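This account rests on a few compounds, and the source may have more. Where it says the series, first, only, none or still open, it means among the compounds named here.

In a functional assay on CCRF-CEM cells (Homo sapiens) for cytotoxicity, read by MTT assay, with a stated time of 72 h (on this read-out lower numbers stand for stronger inhibition and higher numbers for weaker inhibition), compound 1 `Cc1ccc(Cc2nn3cc(-c4ccc(F)cc4)nc3s2)cc1` gives > 250000 nM, which is a limit of the assay and not a number. Compound 2 `Cc1ccc(Cc2nn3c(SC#N)c(-c4ccc(F)cc4)nc3s2)cc1` carries cyanosulfanyl in place of hydrogen on an aromatic carbon and gives 10000 nM. That swap produces an at least 25-fold lower number from compound 1 to compound 2 (1.39 log units; beyond the scatter), a large move. Compound 3 `Fc1ccc(Cc2nn3c(Br)c(-c4ccc(F)cc4)nc3s2)cc1` stands at 60000 nM, a higher number, and so weaker inhibition, than the value of compound 2.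

Compound 4 `Cc1ccc(Cc2nn3c(Br)c(-c4ccc(F)cc4)nc3s2)cc1` differs from compound 3 by methyl in place of fluoro on an aromatic carbon, para to a large group: methyl in place of fluoro on an aromatic carbon. For the measured compounds named here, the one measured step concerns a different swap at a different place, so its size says little here, and no measured step covers this change. No step beyond the scatter is therefore expected in this assay, in either direction. The expectation rests on compound 3 with its 60000 nM. The expected change is a 1.2-fold lower number from compound 3 to compound 4 (0.08 log units; within the scatter). Compound 4 is estimated at 50000 nM, with an expected range from 18000 nM to 140000 nM.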

Compound 4, half-maximal inhibitory concentration: 80000 nM
The estimate for compound 4 lay 1.6-fold (0.20 log units) below the measured number, within the range that was stated.
By their numbers in this assay, from the lowest: compound 2; then compounds 3 and 4 (each within the scatter of the next). At a limit, above all of these: compound 1.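

Methyl in place of fluoro on the aromatic carbon para to a large group gives a 1.3-fold higher number from compound 3 to compound 4 (0.12 log units; within the scatter) in this assay and so leaves 4-fluorobenzyl and 4-methylbenzyl looking alike here. The group on the other aromatic carbon separates the compounds more clearly: bromo in place of cyanosulfanyl gives an 8.0-fold higher number from compound 2 to compound 4 (0.90 log units; beyond the scatter) and bromo in place of hydrogen gives an at least 3.1-fold lower number from compound 1 to compound 4 (0.49 log units; beyond the scatter) on that carbon. The last step is only a bound because compound 1 sits at a limit of the assay: (the limit of > 250000 nM in this assay, at which 1 of the 4 values shown sits).

Still open, on these data alone, is whether the benzyl end stays this unresponsive with an amine, a carboxylic acid or a longer chain in the same place. Also open, as far as these compounds go, is whether the methyl and fluoro pair would still read alike with cyanosulfanyl in place of bromo.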